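The compounds below may be only part of what the source reports. "The series", "measured", "known", "first", "only" and "open" are said of these compounds alone.

Compound 1 `COc1ccc(CN(C(=O)CSc2ccccn2)c2cc(OC)c(OC)c(OC)c2)cc1` is tested in a functional assay on PC-3 cells (Homo sapiens) for antiproliferative activity, read by MTT assay, with a stated time of 48 h (on this read-out lower numbers stand for stronger inhibition and higher numbers for weaker inhibition), where compound 1 gives 7510 nM. Of the three numbers measured, compound 1 holds the second highest: compound 3 `COc1ccc(CN(C(=O)CSc2nncs2)c2cc(OC)c(OC)c(OC)c2)cc1` gives 5530 nM, a gap within the scatter, while compound 2 `COc1ccc(CN(C(=O)CCSc2nc3ccccc3o2)c2cc(OC)c(OC)c(OC)c2)cc1` gives 20200 nM. Compound 4 `COc1ccc(CN(C(=O)CCCSc2nc3ccccc3o2)c2cc(OC)c(OC)c(OC)c2)cc1` differs from compound 1 in one place: 2-((1,3-benzoxazol-2-yl)sulfanyl)ethyl in place of (pyridin-2-yl)sulfanyl on a saturated chain carbon bound to a carbonyl carbon. The step that bears on this is a 2.7-fold higher number from compound 1 to compound 2 (0.43 log units; beyond the scatter), in which ((1,3-benzoxazol-2-yl)sulfanyl)methyl entered in the same place; a 3.7-fold lower number from compound 2 to compound 3 (0.56 log units; beyond the scatter) points the same way. With 2-((1,3-benzoxazol-2-yl)sulfanyl)ethyl entering, a number at least as high as compound 2 is expected, so the expected step is a 3.3-fold higher number from compound 1 to compound 4 (0.52 log units; beyond the scatter). Compound 4 is therefore estimated at 25000 nM, with a range from 10000 nM to 60000 nM.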

Compound 4, half-maximal inhibitory concentration: 32700 nM
For compound 4 the middle estimate is 1.3-fold (0.12 log units) below the measured one; measured number inside the range.
By their numbers in this assay, from the lowest: compounds 3 and 1 (each within the scatter of the next); then compounds 2 and 4 (each within the scatter of the next).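

In this assay, adding one more carbon to the chain that carries the (1,3-benzoxazol-2-yl)sulfanyl group gives no readable change, with a 1.6-fold higher number from compound 2 to compound 4 (0.21 log units; within the scatter). The weaker result still holds against the smaller groups, with a 4.4-fold higher number from compound 1 to compound 4 (0.64 log units; beyond the scatter) and a 5.9-fold higher number from compound 3 to compound 4 (0.77 log units; beyond the scatter). Length alone therefore shows no further effect once the (1,3-benzoxazol-2-yl)sulfanyl group is present. On these data alone, it remains open whether the 1,3-benzoxazol-2-yl ring or the longer chain drives these steps, and how a (pyridin-2-yl)sulfanyl group on a longer chain or an amine in this place would read. No measurement shown gives a reason for these steps.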